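The source may report more compounds than this note shows. Statements on the series, on what has been measured and on what is new or still open speak of the compounds shown alone.

Measured compounds:
- compound 1, `Brc1ccc(-c2cn3ccnc3c(-c3ccc4ncn(C5CCCCC5)c4c3)n2)cc1`: 34%
- compound 2, `CCc1ccc(-c2cn3ccnc3c(-c3ccc4ncn(Cc5ccccc5)c4c3)n2)cc1`: 30.7%

Two compounds of this series have been run in a functional assay on RXF 393 cells (Homo sapiens) for inhibition, read by sulforhodamine B assay, with a stated time of 48 h, tested at 10 uM; a lower number here means less inhibition, a higher number more inhibition at the concentration tested (going by the name of the read-out). Compound 1, `Brc1ccc(-c2cn3ccnc3c(-c3ccc4ncn(C5CCCCC5)c4c3)n2)cc1`, gives 34% in this assay. Compound 2, `CCc1ccc(-c2cn3ccnc3c(-c3ccc4ncn(Cc5ccccc5)c4c3)n2)cc1`, gives 30.7% in this assay. On the two numbers shown, compound 2 has the lower one, but its gap to compound 1 lies within the scatter of repeated measurements, so the two values show no order between them and nothing can be said about the change in the group on the core nitrogen.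

The next compound, compound 3, `O=Cc1ccc(-c2cn3ccnc3c(-c3ccc4ncn(Cc5ccccc5)c4c3)n2)cc1`, has not yet been run in this assay. Its difference from compound 2 is formyl in place of ethyl on an aromatic carbon. Among the measured compounds shown here, there is no measured step that would show what such a change does, so there is no basis for expecting a step beyond the scatter in either direction; the expectation is that compound 3 stays near the two values already seen.

Compound 3 is therefore expected to give about 32% in this assay, within a range from 15% to 50%. The estimated step of a number 1.3 percentage points higher from compound 2 to compound 3 (within the scatter) is expected to be none beyond the scatter.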

Compound 3, a percentage reported as inhibition, at one concentration (the size of the read-out at that concentration, not a potency): 25%
For compound 3 the middle estimate is 7 percentage points above the measured one; low and high end bracket the measured number.
By their numbers in this assay, from the lowest: compounds 3, 2 and 1 (each within the scatter of the next).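

Among the compounds shown here, compounds 2 and 3 form the first pair that differs in one place only. In this assay, the change from 4-ethylphenyl to 4-formylphenyl gives a number 5.7 percentage points lower from compound 2 to compound 3 (within the scatter), so replacing ethyl with formyl on this aromatic carbon, para to a large group, has no readable effect on the read-out, even though it brings in a carbonyl and a hydrogen-bond acceptor. For the compounds shown here, with the benzyl group on the core nitrogen held fixed, this one exchange therefore leaves the two compounds indistinguishable; compound 1 differs from each of them in more than one place, so no step to it can be read.

As far as these compounds go, it remains open whether an amine, a carboxylic acid or a longer chain at this same place, or a group other than benzyl or cyclohexyl on the core nitrogen on its own, would give a step beyond the scatter. No measurement is at hand that bears on the result for compound 3.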